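A few compounds are considered here, and "the series" means these few. Any claim that something is new, unique, unknown or untested is made for them only; others in the source may bear on it.

Measured so far in an assay on a protein complex for inhibition of CDK8/Cyclin C (Homo sapiens), with a stated time of 1 h; on this read-out higher numbers stand for weaker inhibition and lower numbers for stronger inhibition:
compound 1 `CNC(=O)/C=C/c1ccncc1-c1ccc2cccnc2c1` gives 1760 nM
compound 2 `CCOC(=O)/C=C/c1ccncc1-c1ccc2c(cnn2C)c1` gives 102 nM
compound 3 `NNC(=O)COc1ccncc1-c1ccc2ccccc2c1` gives "not determined" (no result reported), that is, no result is reported for it

Compound 2 holds the lowest of the two numbers in this assay; the nearest, compound 1, sits a long way higher, beyond the scatter. For the measured compounds named here, no two measured compounds differ in a single place, so no step size is available from the data.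

Compound 4 `Cn1ncc2cc(-c3cnccc3/C=C/C(=O)N3CCOCC3)ccc21` is not yet measured. It differs from compound 2 by morpholin-4-yl in place of ethoxy on a carbonyl carbon — morpholin-4-yl in place of ethoxy on a carbonyl carbon. Nothing measured speaks to an ester-to-amide exchange on this core. The expectation is a modest step, likely weaker, a 2.5-fold higher number from compound 2 to compound 4 (0.39 log units; beyond the scatter). Compound 4 is expected to give 250 nM in this assay, within 60 nM to 1000 nM.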

Compound 4, half-maximal inhibitory concentration: 356 nM
Compound 4: middle estimate off by 1.4-fold (0.15 log units), on the low side, within the range that was stated.
By their numbers in this assay, from the lowest: compound 2; then compound 4; then compound 1.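

In this assay, for the compounds shown here, morpholin-4-yl in place of ethoxy on a carbonyl carbon gives a 3.5-fold higher number from compound 2 to compound 4 (0.54 log units; beyond the scatter), the first single-place step. The change is modest and beyond the scatter, so this carbonyl position affects the read-out, yet it still accepts an amide with a ring in place of the ester. No measurement available here accounts for the step.

As far as these compounds go, whether the shift follows from the amide link or from the morpholine ring stays open. A piperidin-1-yl amide, a dimethylamide or a carboxylic acid on the same core would separate these.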